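The compounds below may be only part of what the source reports. "The series", "measured", "known", "first", "only" and "open" are said of these compounds alone.

Compound 1 `CC1CCCN1C1CCN(c2ccc(NC(=O)CC3CCCC3)cc2)C1` is the reference point of this small set: in an assay on CHO cells for displacement of a labelled ligand from histamine receptor H3 (Macaca mulatta) (a lower number here means a stronger inhibitor, a higher number a weaker inhibitor), compound 1 gives 3.1 nM. Compound 2 `CC1CCCN1C1CCN(c2ccc(NC(=O)C3CC3)cc2)C1` differs from it by cyclopropyl in place of cyclopentylmethyl on a carbonyl carbon, and in this assay compound 2 gives 9.7 nM, a step of a 3.1-fold higher number from compound 1 to compound 2 (0.50 log units; beyond the scatter). Compound 3 `Cc1cc(NC(=O)CC2CCCC2)ccc1N1CCC(N2CCCC2C)C1` keeps the original amide but differs from compound 1 by methyl in place of hydrogen on an aromatic carbon; in this assay compound 3 gives 10.7 nM, a step of a 3.5-fold higher number from compound 1 to compound 3 (0.54 log units; beyond the scatter). The values of compound 2 and compound 3 lie within the usual scatter of each other, so nothing separates them.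

Compound 4 `Cc1cc(NC(=O)C2CC2)ccc1N1CCC(N2CCCC2C)C1` has not yet been measured. It differs from compound 3 by cyclopropyl in place of cyclopentylmethyl on a carbonyl carbon, on the core of compound 3. This is the same change that separates compound 1 from compound 2, and the place is described identically in both cases. The expectation for compound 4 therefore rests on the step seen from compound 1 to compound 2, a 3.1-fold higher number from compound 1 to compound 2 (0.50 log units; beyond the scatter), applied to the value of compound 3. Compound 4 is expected to show a step of a 3.1-fold higher number from compound 3 to compound 4 (0.49 log units; beyond the scatter) in this assay. In this assay compound 4 is thus estimated at 33 nM, with a likely range from 12 nM to 90 nM.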

Compound 4, inhibition constant: 17.7 nM
The estimate for compound 4 lay 1.9-fold (0.27 log units) above the measured number; the range from low to high includes it.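

In this assay, cyclopropyl in place of cyclopentylmethyl on a carbonyl carbon gives a 1.7-fold higher number from compound 3 to compound 4 (0.22 log units; within the scatter) on the core of compound 3, and this reading does not differ from the earlier one on the core of compound 1: the same change on two cores in this assay, a 3.1-fold higher number (0.50 log units; beyond the scatter) from compound 1 to compound 2 and a 1.7-fold higher number (0.22 log units; within the scatter) from compound 3 to compound 4, 1.9-fold (0.28 log units) apart, within the scatter of two such steps. Methyl in place of hydrogen on an aromatic carbon, now read with the cyclopropyl group in place, gives a 1.8-fold higher number from compound 2 to compound 4 (0.26 log units; within the scatter), and it likewise agrees with its earlier reading: the same change on two cores in this assay, a 3.5-fold higher number (0.54 log units; beyond the scatter) from compound 1 to compound 3 and a 1.8-fold higher number (0.26 log units; within the scatter) from compound 2 to compound 4, 1.9-fold (0.28 log units) apart, within the scatter of two such steps. The earlier and new steps are therefore compatible across these cores, but this does not show that either change keeps its full size, since each new step is within the scatter on its own and each comparison rests on a single pair of steps.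

As far as these compounds go, it remains open whether a longer chain or a phenyl group on the carbonyl carbon would carry from one core to the other in the same way. The same question stands for chlorine or methoxy in place of methyl on the aromatic carbon.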